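This account rests on a few compounds, and the source may have more. Where it says the series, first, only, none or still open, it means among the compounds named here.

Measured so far:
- compound 1, `CC(=O)c1ccc(CNC(=O)c2ccc(C(C)(C)C)cc2)cc1`: 100 nM
- compound 2, `Cc1cc(CNC(=O)c2ccc(C(C)(C)C)cc2)ccc1C(=O)O`: 160 nM
- compound 3, `CC(C)(C)c1ccc(C(=O)NCc2cccc(C(=O)O)c2)cc1`: 1700 nM

In an assay on HeLa cells with Bile acid receptor (Homo sapiens) as the target, read by a luciferase reporter, with a stated time of 24 h (a lower number here means that less compound is needed, a higher number that more compound is needed for the effect), compound 1 gives 100 nM, the lowest of the three numbers. Compound 2, with 160 nM, sits close enough that the two cannot be told apart within the usual scatter of this assay, so neither can be called the stronger of the pair. Compound 3, with 1700 nM, stands clearly further off, beyond the scatter.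

Compound 4, `CC(C)(C)c1ccc(C(=O)NCc2ccc(S(C)(=O)=O)cc2)cc1`, has not yet been measured. It differs from compound 1 in one place: methylsulfonyl in place of acetyl on an aromatic carbon. The change sits on an aromatic carbon of a six-membered aromatic ring of carbon only, para to a large group, and the rest of the molecule is unchanged.

Within the data shown here, no measured pair shows the effect of this exact swap, so the expectation rests only on the closeness of compound 1 and compound 2. A small step, if any, is expected from compound 1 to compound 4 in this assay, a 2.0-fold higher number from compound 1 to compound 4 (0.30 log units; within the scatter), probably not beyond the scatter. Compound 4 is therefore estimated at 200 nM, with a plausible range from 60 nM to 700 nM.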

Compound 4, half-maximal effective concentration: 3800 nM
Beside the measured number, compound 4's estimate is 19-fold (1.28 log units) below it; measured number above the stated range.
By their numbers in this assay, from the lowest: compounds 1 and 2 (each within the scatter of the next); then compound 3; then compound 4.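

In this assay, among these compounds, this aromatic carbon proves sensitive to what it carries: methylsulfonyl in place of acetyl gives a 38-fold higher number from compound 1 to compound 4 (1.58 log units; beyond the scatter), a large step that the earlier compounds could not reveal, as none of them formed a one-place pair. The two groups look alike on paper, since both carry no net charge, contain no ring and have no hydrogen-bond donors, so a swap between such similar groups can still shift the number a long way. Nothing measured here accounts for the size of this step.

As far as these compounds go, it remains open whether only methylsulfonyl gives so high a number at this position, or whether other replacements for acetyl would do the same. A nitrile, an amine or a sulfonamide on the same carbon, with the rest of compound 1 unchanged, would help to answer this.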